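From 4-phenylphenyl to 4-methoxyphenyl: an expected flat step

The source may hold more compounds than are shown below. What is called first, only, known or untested is meant among the compounds shown, and "the series" means these compounds.

Going by the values given here, in a functional assay on HCT-116 cells (Homo sapiens) for inhibition, read by MTT assay, with a stated time of 72 h (on this read-out higher numbers stand for weaker inhibition and lower numbers for stronger inhibition), compound 1 (`O=C1/C(=C\c2ccccc2)c2c(ncn2COCc2ccccc2)CCN1Cc1ccc(F)cc1`) gives 11200 nM and compound 2 (`O=C1/C(=C\c2ccccc2)c2c(ncn2COCc2ccccc2)CCN1Cc1ccc(-c2ccccc2)cc1`) gives 14000 nM as the only two numbers so far. Compound 2 therefore stands level with compound 1, within the scatter, and no ranking can be drawn between them.

Compound 3 (`COc1ccc(CN2CCc3ncn(COCc4ccccc4)c3/C(=C/c3ccccc3)C2=O)cc1`) differs from compound 2 by methoxy in place of phenyl on an aromatic carbon and so reads as methoxy in place of phenyl on an aromatic carbon, para to a large group. Among the compounds with values here, the same aromatic carbon has already carried both fluoro and phenyl, and the one measured step that bears on it is a 1.3-fold higher number from compound 1 to compound 2 (0.10 log units; within the scatter) for phenyl in place of fluoro. Within the data shown here, no methoxy compound has been measured, so this single step is thin support. Even so, no step beyond the scatter is expected in this assay in either direction.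

The estimated step is a 1.2-fold lower number from compound 2 to compound 3 (0.07 log units; within the scatter) and it is expected to stay within the scatter. Compound 3 is estimated at 12000 nM with an expected range of 5000 nM to 28000 nM in this assay on this reading.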

Compound 3, half-maximal inhibitory concentration: 31100 nM
For compound 3 the middle estimate is 2.6-fold (0.41 log units) below the measured one, outside the stated range (above it).
By their numbers in this assay, from the lowest: compounds 1 and 2 (each within the scatter of the next); then compound 3.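

In this assay, going by these compounds alone, this aromatic carbon, para to a large group, no longer reads as flat: the change gives a 2.2-fold higher number from compound 2 to compound 3 (0.35 log units; beyond the scatter), and measured against the fluoro compound it gives a 2.8-fold higher number from compound 1 to compound 3 (0.44 log units; beyond the scatter), whereas the only earlier step, a 1.3-fold higher number from compound 1 to compound 2 (0.10 log units; within the scatter), showed no ranking. Of the three groups tested here, methoxy alone separates from the others, with fluoro and phenyl remaining level, so the read-out at this position depends on the group it carries, and the change to methoxy weakens inhibition modestly. Methoxy brings one hydrogen-bond acceptor where phenyl brings none, but three compounds cannot tie the step to that count, and no supporting data explain the step.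

Going by these compounds, whether a hydroxyl, an amine or a carboxylic acid on this carbon would sit with methoxy or stay level with fluoro and phenyl remains open. Also open, on these data alone, is whether a longer chain such as ethoxy would take the number further from that of compound 2, or whether methoxy would give the same step on a different core.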